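The source may report more compounds than this note shows. Statements on the series, on what has been measured and on what is new or still open speak of the compounds shown alone.

Measured so far in an ADME assay on RAW264.7 cells (Mus musculus) for cytotoxicity, read by MTT assay, with a stated time of 24 h; on this read-out higher numbers stand for lower toxicity in this test and lower numbers for higher toxicity in this test:
- compound 1 `COc1ccc(C2CC(c3ccc(C)c(C)c3)=NN2C2=NC(=O)CS2)cc1`: 387000 nM
- compound 2 `Cc1ccc(C2=NN(C3=NC(=O)CS3)C(c3ccccc3)C2)cc1C`: the result is a limit of the assay, > 450000 nM
- compound 3 `COc1ccc(C2CC(c3ccc(Cl)c(Cl)c3)=NN2C2=NC(=O)CS2)cc1`: 264000 nM

Compound 1 and compound 3 share one core and differ by 3,4-dichlorophenyl in place of 3,4-dimethylphenyl on a carbon with a double bond to nitrogen, which gave a 1.5-fold lower number from compound 1 to compound 3 (0.17 log units; within the scatter) in this assay. Compound 2 carries the change hydrogen in place of methoxy on an aromatic carbon relative to compound 1; the step of an at least 1.1-fold higher number from compound 1 to compound 2 (0.06 log units; that floor lies within the scatter) is bounded by the limit of > 450000 nM in this assay, at which 1 of the 3 values shown sits, so its true size is open.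

Compound 4 `O=C1CSC(N2N=C(c3ccc(Cl)c(Cl)c3)CC2c2ccccc2)=N1` is not yet measured. It differs from compound 3 by hydrogen in place of methoxy on an aromatic carbon, the same change as from compound 1 to compound 2; the place is the same in both pairs. Compound 3 stands lowest of the two numbers, nearest compound 1.

For compound 4 the step of a 1.4-fold higher number from compound 3 to compound 4 (0.16 log units; within the scatter) is expected, with a sizable chance that only a limit is returned. This expectation rests on the measured step of an at least 1.1-fold higher number from compound 1 to compound 2 (0.06 log units; that floor lies within the scatter), which runs in the same direction. Compound 4 is estimated at 380000 nM, between 200000 nM and 700000 nM, resting on compound 3 at 264000 nM and the step of an at least 1.1-fold higher number from compound 1 to compound 2 (0.06 log units; that floor lies within the scatter).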

Compound 4, half-maximal cytotoxic concentration: 295000 nM
Compound 4: middle estimate off by 1.3-fold (0.11 log units), on the high side, and the stated range covers the measured number.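

In this assay, hydrogen in place of methoxy on the core carrying 3,4-dichlorophenyl gave a 1.1-fold higher number from compound 3 to compound 4 (0.05 log units; within the scatter), and 3,4-dichlorophenyl in place of 3,4-dimethylphenyl on the core lacking the methoxy gave an at least 1.5-fold lower number from compound 2 to compound 4 (0.18 log units; that floor lies within the scatter). The hydrogen-for-methoxy change therefore shows no step beyond the scatter on the core of compound 3, and its comparison with the core of compound 1 remains unresolved: the same change on two cores in this assay, an at least 1.1-fold higher number (0.06 log units; that floor lies within the scatter) from compound 1 to compound 2 and a 1.1-fold higher number (0.05 log units; within the scatter) from compound 3 to compound 4; the limit leaves it open whether they differ The aryl exchange is likewise not shown either to carry over unchanged or to differ between the two cores: the same change on two cores in this assay, a 1.5-fold lower number (0.17 log units; within the scatter) from compound 1 to compound 3 and an at least 1.5-fold lower number (0.18 log units; that floor lies within the scatter) from compound 2 to compound 4; the limit leaves it open whether they differ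

The compounds shown leave open whether a group other than methoxy or hydrogen at the place para to a large group, such as an amine, a carboxylic acid or a longer chain, would give a step beyond the scatter. They also leave open what number compound 2 would give in place of its limit, and so how large the two steps that reach it really are.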